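Trading a Chain Hydroxyl for a Terminal Aldehyde

The compounds below may be only part of what the source reports. "The series", "measured", "known", "first", "only" and "open" are said of these compounds alone.

Two compounds of a shared core, each carrying a long chain on a double-bonded chain carbon, have been tested for how strongly they slow the growth of a human leukemia cell line. In a functional assay on MOLT-4F cells (Homo sapiens) for antiproliferative activity (a higher number here means a weaker inhibitor of growth, a lower number a stronger inhibitor of growth), compound 1, `CC(=O)OCCCCCCCCCCCCCCC/C=C1\CC(CO)(COC(=O)C(C)(C)C)OC1=O`, gives 1.55 ug/mL, and compound 2, `CCCCCCCCC(O)CCCCCC/C=C1\CC(CO)(COC(=O)C(C)(C)C)OC1=O`, gives 7.91 ug/mL. Compound 2 therefore stands at the weaker end of the two numbers seen so far, and its distance from compound 1 lies beyond the scatter of repeated measurements. Compound 3, `CC(C)(C)C(=O)OCC1(CO)C/C(=C\CCCCCCCCCCCCCCC=O)C(=O)O1`, has not yet been measured. It differs from compound 2 in one place: 8-formyloctyl in place of 1-hydroxynonyl on a saturated chain carbon, six bonds along the chain from a double-bonded chain carbon. Like compound 1, compound 3 carries no hydrogen-bond donor on its chain, and compound 1 gives the stronger number of the two measured. On that basis a step of moderate size toward stronger growth inhibition is expected from compound 2 to compound 3, namely a 2.8-fold lower number from compound 2 to compound 3 (0.45 log units; beyond the scatter), though it could fall within the scatter. For compound 3 the estimated value in this assay is 2.8 ug/mL, expected to lie between 1 ug/mL and 7 ug/mL.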

Compound 3, concentration for 50% growth inhibition: > 10 ug/mL
Compound 3: a limit, no number; the forecaster's own chance of this, stated with the estimate: 3%; at least 3.5-fold (0.55 log units) between middle value and limit.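

In this assay compound 3 gives a limit and not a number: the limit of > 10 ug/mL in this assay, at which 1 of the 3 values shown sits.

Replacing 1-hydroxynonyl with 8-formyloctyl at this place on the chain gives an at least 1.2-fold higher number from compound 2 to compound 3 (0.10 log units; that floor lies within the scatter), so the change brought no sign of stronger growth inhibition, although the printed floor alone cannot show that growth inhibition became weaker. Ending the chain in formyl rather than acetoxymethyl gives an at least 6.4-fold higher number from compound 1 to compound 3 (0.80 log units; beyond the scatter), which shows that two chains with 0 hydrogen-bond donors can sit far apart in this assay, and that the absence of a donor does not by itself go with the stronger number.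

The compounds shown leave open how a terminal carboxylic acid or a terminal amine on the same long chain would read in this assay. They also leave open the real distance between compound 3 and compound 2, since a limit marks only where the reading stops and cannot settle whether the formyl chain truly costs growth inhibition.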